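The source may hold more compounds than are shown below. What is called first, only, known or untested is meant among the compounds shown, and "the series" means these compounds.

In a functional assay on Huh-7 cells (Homo sapiens) for cytotoxicity, read by MTT assay, with a stated time of 3 days (a higher number here means that more compound is tolerated, a lower number that less compound is tolerated), two compounds sharing one core have been measured. Compound 1 `[N-]=[N+]=NCc1ncnc2c1ncn2[C@@H]1O[C@H](CO)[C@@H](O)[C@H]1O` gives > 250000 nM, which is a limit and not a number. Compound 2 `O=C(O)CNCc1ncnc2c1ncn2[C@@H]1O[C@H](CO)[C@@H](O)[C@H]1O` gives > 100000 nM, which is also a limit. Compound 2 therefore has no exact value, and the only other result shown is likewise a limit. Compound 3 `OC[C@H]1O[C@@H](n2cnc3c(Cn4cccn4)ncnc32)[C@H](O)[C@@H]1O` keeps the core and changes one group on a saturated chain carbon bound to an aromatic carbon: 1H-pyrazol-1-yl in place of (carboxymethyl)amino on a saturated chain carbon bound to an aromatic carbon. The 1H-pyrazol-1-yl group brings one five-membered aromatic ring in place of the open (carboxymethyl)amino group. Going by the values given here, the only measured change at this place is a step that the two limits leave unreadable from compound 1 to compound 2, so it gives neither a size nor a direction. With no direction to follow, the expected result is no clear shift, an estimated a number no higher from compound 2 to compound 3 (the limit leaves the size open). The expected value for compound 3 is 100000 nM, within an estimated range of 25000 nM to 250000 nM.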

Compound 3, half-maximal cytotoxic concentration: > 250000 nM
Compound 3: no number, only a limit (the forecaster's own chance of this, stated with the estimate: 70%); at least 2.5-fold (0.39 log units) between middle value and limit.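

Compound 3 gives only a limit, as do compound 1 and compound 2, so no step among these three compounds can be read. The compounds shown leave open whether swapping these groups changes the tolerated concentration at all, and if so, in which direction and by how much.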